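The source may hold more compounds than are shown below. What is called first, only, known or untested is meant among the compounds shown, and "the series" means these compounds.

Measured compounds

Compound 1, `CCOc1ccccc1N1CCN(CCCCCCCn2ncc(N3CCN(C(=O)c4ccco4)CC3)c(Cl)c2=O)CC1`, in an assay on cell membranes for binding affinity to Adrenergic receptor alpha-1 (Rattus norvegicus), read by radioligand binding (on this read-out lower numbers stand for stronger inhibition and higher numbers for weaker inhibition), compound 1 gives 0.5 nM.
Compound 2, `CCOc1ccccc1N1CCN(CCCCCCCn2ncc(Cl)c(N3CCN(C(=O)c4ccco4)CC3)c2=O)CC1`, in this assay compound 2 gives 0.23 nM.
Compound 3, `CCOc1ccccc1N1CCN(CCCCCCCn2ncc(N3CCN(CC4COc5ccccc5O4)CC3)c(Cl)c2=O)CC1`, in this assay compound 3 gives 0.42 nM.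

Compounds 1 and 2 are built from the same atoms joined differently; the difference between the two cores is not broken down here. Compound 2 has the lowest of the three numbers, and its gap to compound 1 lies beyond the scatter, while its gap to compound 3 lies within it, so no order is claimed between compound 2 and compound 3.

From compound 1 to compound 3 the change is (2,3-dihydro-1,4-benzodioxin-2-yl)methyl in place of (furan-2-yl)carbonyl on an amine nitrogen in a ring, and this step gives a 1.2-fold lower number from compound 1 to compound 3 (0.08 log units; within the scatter), a difference within the scatter.

The unmeasured compound 4, `CCOc1ccccc1N1CCN(CCCCCCCn2ncc(Cl)c(N3CCN(CC4COc5ccccc5O4)CC3)c2=O)CC1`, is related to compound 2 by the same change, ((2,3-dihydro-1,4-benzodioxin-2-yl)methyl in place of (furan-2-yl)carbonyl on an amine nitrogen in a ring). The place is the same in both pairs, so the change is the same one, carried out on the core of compound 2 rather than the core of compound 1.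

Since the step from compound 1 to compound 3 was a 1.2-fold lower number from compound 1 to compound 3 (0.08 log units; within the scatter), the expectation for compound 4 in this assay is a step of about a 1.2-fold lower number from compound 2 to compound 4 (0.06 log units; within the scatter), roughly a flat outcome beside the earlier one. The estimate for compound 4 in this assay is therefore 0.2 nM, expected to fall between 0.08 nM and 0.5 nM.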

Compound 4, inhibition constant: 0.43 nM
For compound 4 the middle estimate is 2.2-fold (0.33 log units) below the measured one; measured number inside the range.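

In this assay, carrying the exchange of (furan-2-yl)carbonyl for (2,3-dihydro-1,4-benzodioxin-2-yl)methyl over to the second core gives a 1.9-fold higher number from compound 2 to compound 4 (0.27 log units; within the scatter), so here too the step stays within the scatter. Set side by side, the two steps cannot be told apart: the same change on two cores in this assay, a 1.2-fold lower number (0.08 log units; within the scatter) from compound 1 to compound 3 and a 1.9-fold higher number (0.27 log units; within the scatter) from compound 2 to compound 4, 2.2-fold (0.35 log units) apart, within the scatter of two such steps. This shows that, on these two cores, the larger group can stand on the amine nitrogen in place of the (furan-2-yl)carbonyl without a step that this read-out can resolve; it does not show that the two cores respond identically, since small differences could lie hidden in the scatter, and two pairs in a single assay give no rule for any other core.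

The compounds shown leave open how a simple acetyl or benzyl group, or a free amine hydrogen, would read on that same ring nitrogen, and whether the flat outcome would hold with a shorter chain in place of the present one or with a bromine in place of the chlorine. They also leave open whether this exchange would stay as flat on any receptor other than the one tested here.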